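Efficacy notes: aryl swap at the thiazole position

The source may hold more compounds than are shown below. What is called first, only, known or untested is meant among the compounds shown, and "the series" means these compounds.

Measured compounds:
compound 1 `O=C(O)Cc1sc(C(c2ccc(F)cc2)c2ccc(F)cc2)nc1-c1ccnc(F)c1`, 80%
compound 2 `NS(=O)(=O)c1cccc(-c2nc(C(c3ccc(F)cc3)c3ccc(F)cc3)sc2CC(=O)O)c1`, 55%

In an in vitro functional assay on HEK285-7 cells for antagonist activity at prostaglandin D2 receptor 2 (Homo sapiens), read by BRET and beta-arrestin recruitment (a lower number here means a smaller maximal response, a higher number a larger maximal response), compound 2 stands lowest of the two numbers; its nearest neighbour is compound 1, which sits higher in this assay by a margin beyond the scatter. Among the compounds with values here, the one measured step that joins them is a number 25 percentage points lower from compound 1 to compound 2 (beyond the scatter).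

Compound 3 `O=C(O)Cc1sc(C(c2ccc(F)cc2)c2ccc(F)cc2)nc1-c1ccncc1` is not yet measured. Its change from compound 2 is pyridin-4-yl in place of 3-sulfamoylphenyl on an aromatic carbon. This reverses the kind of substitution seen in the measured step, since compound 3 carries a pyridin-4-yl where compound 1 carries a 2-fluoropyridin-4-yl, and compound 2 carries the 3-sulfamoylphenyl that accompanied the lower number. The measured step bears directly on it and was modest; an increase of similar size is therefore expected, so that the step from compound 2 to compound 3 is estimated at a number 20 percentage points higher from compound 2 to compound 3 (beyond the scatter). Compound 3 is expected to give 75%, with a range from 60% to 90%.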

Compound 3, largest response reached (reported as efficacy), in percent of the reference or control that the assay uses: 80%
The estimate for compound 3 lay 5 percentage points below the measured number; the range from low to high includes it.
By their numbers in this assay, from the lowest: compound 2; then compounds 1 and 3 (each within the scatter of the next).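

In this assay, hydrogen in place of fluoro on the pyridine ring gives no change at the digits printed from compound 1 to compound 3 (within the scatter), so at this position the fluoro group makes no difference that can be read. The change of whole aryl group does make one: pyridin-4-yl in place of 3-sulfamoylphenyl gives a number 25 percentage points higher from compound 2 to compound 3 (beyond the scatter), so the lower number of compound 2 now stands against two pyridine-bearing compounds rather than one. Nothing at hand accounts for this step.

The compounds shown leave open whether the lower number goes with the sulfamoyl group or with the six-membered ring of carbon only, a question that a plain phenyl would help to settle. A 3-aminophenyl or a 3-carboxyphenyl at the same carbon would show whether other groups on that ring give a similar number.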